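One side group changed on a potent inhibitor

The compounds below may be only part of what the source reports. "The series", "measured", "known", "first", "only" and "open" are said of these compounds alone.

Compound 1 `COC(=O)Nc1nc2ccc(C(=O)c3cccs3)cc2n1C` gives 40000 nM
Compound 2 `COC(=O)Cc1csc(C(=O)c2ccc3[nH]c(NC(=O)OC)nc3c2)c1` gives 40 nM

Both numbers come from a functional assay on B16 cells (Mus musculus) for inhibition (a higher number here means a weaker inhibitor, a lower number a stronger inhibitor), and compound 2 has the lower of the two, with a gap to compound 1 well beyond the scatter. Compound 3 `COC(=O)Nc1nc2cc(C(=O)c3cc(C(=O)C(F)(F)F)cs3)ccc2[nH]1` has not yet been measured. It keeps the shared core of compound 2 and alters one group, as counted here: (trifluoromethyl)carbonyl in place of (methoxycarbonyl)methyl on an aromatic carbon and the swap puts (trifluoromethyl)carbonyl in place of (methoxycarbonyl)methyl on an aromatic carbon. That carbon belongs to a five-membered aromatic ring with 1 sulfur, two ring bonds from the ring sulfur.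

Going by the values given here, no measured pair isolates a change like this one, so any expectation is rough. Compound 2 at 40 nM sets the starting point, and a low number has more room to rise than to fall. In this assay a moderate rise is expected, meaning a somewhat weaker inhibitor, just beyond the scatter. The estimated move is a 3.0-fold higher number from compound 2 to compound 3 (0.48 log units; beyond the scatter) and it remains uncertain. For compound 3 the estimated value is 120 nM with an expected range from 25 nM to 800 nM in this estimate.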

Compound 3, half-maximal inhibitory concentration: 140 nM
For compound 3 the middle estimate is 1.2-fold (0.07 log units) below the measured one; low and high end bracket the measured number.
By their numbers in this assay, from the lowest: compound 2; then compound 3; then compound 1.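

In this assay, this place on the five-membered aromatic ring with 1 sulfur, two ring bonds from the ring sulfur, turns out not to depend on the (methoxycarbonyl)methyl group alone. Replacing that group with (trifluoromethyl)carbonyl produces a 3.5-fold higher number from compound 2 to compound 3 (0.54 log units; beyond the scatter) and so costs some inhibition, but only a modest amount. The change is a substantial one on paper, since a chain with two hydrogen-bond acceptors gives way to one with a single acceptor and three fluorine atoms, yet compound 3 still inhibits clearly, and no measurement available here explains the size of this step.

Going by these compounds alone, a single swap gives only one step at this place, so it remains open whether an amine, a carboxylic acid or a longer chain would keep the number as low as that of compound 2 or raise it much further. The roles of the fluorine atoms and of the carbonyl also remain unseparated, and a plain acetyl group, with a methyl in place of the trifluoromethyl, would be the direct comparison for compound 3.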